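Methoxy in place of bromo: a step without precedent

The source may hold more compounds than are shown below. What is called first, only, known or untested is meant among the compounds shown, and "the series" means these compounds.

Three compounds have been measured in a functional assay on MCF7 cells (Homo sapiens) for inhibition, read by MTT assay, with a stated time of 48 h, tested at 10 uM; a lower number here means less inhibition of growth, a higher number more inhibition of growth at the concentration tested:
compound 1 `O=C(/C=C/c1ccc(OCc2cn(Cc3ccccc3Br)nn2)cc1)c1ccc(Br)cc1`: 44%
compound 2 `O=C(/C=C/c1ccc(OCc2cn(Cc3cccc(Br)c3)nn2)cc1)c1ccc(Br)cc1`: 36%
compound 3 `O=C(/C=C/c1ccc(OCc2cn(Cc3ccc(Br)cc3)nn2)cc1)c1ccc(Br)cc1`: 23%

Compound 1 gives the highest of the three numbers; compound 2 lies nearest, a number 8 percentage points lower from compound 1 to compound 2 (within the scatter), and compound 3 furthest, a number 21 percentage points lower from compound 1 to compound 3 (beyond the scatter). Compound 3 also lies below compound 2, a number 13 percentage points lower from compound 2 to compound 3 (beyond the scatter). Compound 4 `COc1ccc(C(=O)/C=C/c2ccc(OCc3cn(Cc4ccccc4Br)nn3)cc2)cc1` differs from compound 1 in methoxy in place of bromo on an aromatic carbon. Within the data shown here, none of the measured steps touches this place: all three move the bromine within the bromophenyl on the saturated chain carbon bound to an aromatic nitrogen. Among the measured compounds shown here, there is therefore no measured step to set the size or direction of this change, and compound 4 is expected to stay near compound 1, a number 2 percentage points lower from compound 1 to compound 4 (within the scatter), not beyond the scatter. Compound 4 is thus estimated at 42%, between 22% and 62%, in this assay.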

Compound 4, percent growth inhibition at one concentration: 60%
Beside the measured number, compound 4's estimate is 18 percentage points below it, within the range that was stated.
By their numbers in this assay, from the lowest: compound 3; then compounds 2 and 1 (each within the scatter of the next); then compound 4.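

In this assay, among these compounds, methoxy in place of bromo gives a number 16 percentage points higher from compound 1 to compound 4 (beyond the scatter), so this aromatic carbon, which no earlier step touched, can change the number. Among the compounds shown here, compound 4 also stands above compound 1, whereas the earlier compounds, which only moved the bromine on the other bromophenyl, reached nothing higher than compound 1. Nothing available here accounts for the rise. Still open, as far as these compounds go, is how an amine, a hydroxy group or a longer chain such as ethoxy would read at this carbon. Also open, from the compounds shown here alone, is whether methoxy would give a similar step on compound 2 or compound 3.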